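Series notes: cinnamate anilides at the bile acid receptor

A few compounds are considered here, and "the series" means these few. Any claim that something is new, unique, unknown or untested is made for them only; others in the source may bear on it.

Measured compounds:
- compound 1 `COC(=O)/C=C/c1cccc(N(Cc2ccc(/C=C/c3c(F)cccc3F)cc2)C(=O)C(C)C)c1`: 108 nM
- compound 2 `COC(=O)/C=C/c1cccc(NC(=O)C2CCCCC2)c1`: > 1000 nM
- compound 3 `COC(=O)/C=C/c1cccc(N(Cc2ccc(/C=C/C(=O)OC(C)(C)C)cc2OC)C(=O)C2CCCCC2)c1`: > 1000 nM

In an assay on isolated protein with Bile acid receptor (Homo sapiens) as the target (a higher number here means that more compound is needed for the effect, a lower number that less compound is needed), compound 1 gives 108 nM. For compound 2 the value > 1000 nM is a limit of this assay, not a number. Compound 3 likewise sits at a limit, > 1000 nM in this assay, so of the three values shown two rest at the limit of > 1000 nM in this assay, at which 2 of the 3 values shown sit, and only compound 1 carries a number; where compound 3 stands relative to compound 1 is therefore known only in direction, not in size.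

Compound 4 `COC(=O)/C=C/c1cccc(N(Cc2ccc(/C=C/C(=O)OC(C)(C)C)cc2O)C(=O)C2CCCCC2)c1` differs from compound 3 by one change: hydrogen in place of methyl on an oxygen on an aromatic ring. Among the measured compounds shown here, no measured pair shows this change, so no size of step can be read off. The expectation is that the step from compound 3 to compound 4, a step that the limit leaves unreadable from compound 3 to compound 4, stays within the scatter, with no clear direction. Compound 4 is accordingly expected to give about 2500 nM in this assay, in a range from 800 nM to 10000 nM, most likely reported again as a limit.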

Compound 4, half-maximal effective concentration: > 1000 nM
Compound 4: only a limit was reported; the forecaster's own chance of this, stated with the estimate: 70%; the middle value is on the limit's open side.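

Compound 3 and compound 4 both rest at an assay limit, so the change from methoxy to hydroxy gives no readable step: the limit of > 1000 nM in this assay, at which 3 of the 4 values shown sit.

The compounds shown leave open the size and direction of that change, and whether it would show on a compound carrying a numbered value.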